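A few compounds are considered here, and "the series" means these few. Any claim that something is new, unique, unknown or untested is made for them only; others in the source may bear on it.

Compound 1 `C[C@H]1CC[C@@H]2[C@@H](OC(=O)[C@]23CC(c2ccccc2Br)=NO3)[C@]2(C)C(=O)C=C[C@@]12O`: 44000 nM
Compound 2 `C[C@H]1CC[C@@H]2[C@@H](OC(=O)[C@]23CC(c2ccccc2Cl)=NO3)[C@]2(C)C(=O)C=C[C@@]12O`: 9000 nM

Within the data shown here, in a functional assay on SW-620 cells (Homo sapiens) for cytotoxicity, read by sulforhodamine B assay, with a stated time of 48 h (on this read-out lower numbers stand for stronger inhibition and higher numbers for weaker inhibition), compound 2 gives 9000 nM, the lower of the two numbers measured so far, so it shows the stronger inhibition of the pair. The next compound to test is compound 3 `C[C@H]1CC[C@@H]2[C@@H](OC(=O)[C@]23CC(c2ccc(C#N)cc2)=NO3)[C@]2(C)C(=O)C=C[C@@]12O`, which keeps the shared core but carries 4-cyanophenyl in place of 2-chlorophenyl on a carbon with a double bond to nitrogen.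

Among the measured compounds shown here, only one measured step bears on this change: a 4.9-fold lower number from compound 1 to compound 2 (0.69 log units; beyond the scatter), with chloro in place of bromo on an aromatic carbon. That modest step shows that swapping a single group on this aromatic ring can move the number in this assay. For the measured compounds named here, no measured compound carries a nitrile, however, or has its aromatic ring substituted at another position, so the guide is rough. Going by the values given here, compound 2 is also the better of only two values, so a modest move towards weaker inhibition seems more likely than a further gain. The expected change is a 2.2-fold higher number from compound 2 to compound 3 (0.35 log units; beyond the scatter). For compound 3 the estimated value is 20000 nM, with an expected range of 5000 nM to 70000 nM.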

Compound 3, half-maximal inhibitory concentration: 53000 nM
Compound 3: middle estimate off by 2.7-fold (0.42 log units), on the low side; the measured number falls inside the stated range.
By their numbers in this assay, from the lowest: compound 2; then compounds 1 and 3 (each within the scatter of the next).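

In this assay, replacing 2-chlorophenyl with 4-cyanophenyl on the carbon with a double bond to nitrogen gives a 5.9-fold higher number from compound 2 to compound 3 (0.77 log units; beyond the scatter). Among these compounds, the earlier compounds showed only one halogen swapped for another, so this is the first sign that a different kind of aromatic group at this place can also weaken inhibition. Against 2-bromophenyl, the same group gives a 1.2-fold higher number from compound 1 to compound 3 (0.08 log units; within the scatter), which leaves compound 1 and compound 3 indistinguishable here, and among these three groups only 2-chlorophenyl stands apart, with the stronger inhibition; no accompanying measurement explains these differences.

Going by these compounds, it remains open whether the weaker inhibition of compound 3 relative to compound 2 goes with the nitrile or with its place on the ring, as 4-cyanophenyl differs from 2-chlorophenyl in both respects, and 4-chlorophenyl and 2-cyanophenyl would be needed to separate the two. Also open, on these data alone, is how other groups on the aromatic ring, such as a methoxy group, an amine or a carboxylic acid, would read in this assay.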